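The compounds below may be only part of what the source reports. "The series", "measured", "known", "first", "only" and "open" are said of these compounds alone.

Among the compounds with values here, compound 1 `COc1cc(-c2cc3ccccc3[nH]2)[nH]c1/C=C1/SC(=O)NC1=O` is the only compound with a definite number in a functional assay on PLC5 cells (Homo sapiens) for cytotoxicity, read by MTT assay; on this read-out higher numbers stand for weaker inhibition and lower numbers for stronger inhibition: compound 1 gives 27500 nM. Compound 2 `COc1cc(-c2cc3ccccc3n2C(=O)OC(C)(C)C)[nH]c1/C=C1/SC(=O)NC1=O` is a close relative, carrying tert-butoxycarbonyl in place of hydrogen on an aromatic nitrogen. In this assay compound 2 reaches only a limit, > 40000 nM. That value is the limit of > 40000 nM in this assay, at which 1 of the 2 values shown sits. Within the data shown here, the one measured step, an at least 1.4-fold higher number from compound 1 to compound 2 (0.16 log units; that floor lies within the scatter), therefore does not rise beyond the scatter. Compound 3 `COc1cc(-c2cc3ccccc3[nH]2)[nH]c1C=C1SCCCS1` differs from compound 1 elsewhere: a group of 7 heavy atoms (5 carbon, 2 sulfur; one six-membered non-aromatic ring with 2 hetero atoms) in place of a group of 8 heavy atoms (4 carbon, 1 nitrogen, 2 oxygen, 1 sulfur; one five-membered non-aromatic ring with 2 hetero atoms), on an aromatic carbon. Among the measured compounds shown here, no measured step touches this part of the core of compound 1, so the single step gives no guidance on the direction of the change, and the expectation is a number near that of compound 1, with a wide range and a fair chance that only a limit is reported. Compound 3 is thus estimated at 30000 nM, between 9000 nM and 100000 nM, an expected step of a 1.1-fold higher number from compound 1 to compound 3 (0.04 log units; within the scatter).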

Compound 3, half-maximal inhibitory concentration: > 40000 nM
Compound 3 gave a limit, no number; the forecaster's own chance of this, stated with the estimate: 40%; middle value at least 1.3-fold (0.12 log units) from the limit.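

The step at this new place on the core of compound 1 reads an at least 1.4-fold higher number from compound 1 to compound 3 (0.16 log units; that floor lies within the scatter), so exchanging the five-membered ring with 2 hetero atoms for the six-membered ring with 2 hetero atoms brings no measurable gain in this assay. As far as these compounds go, its true size stays unknown, since only a floor can be read. Changes at two different places have now each ended at a limit rather than a number: the limit of > 40000 nM in this assay, at which 2 of the 3 values shown sit.

The compounds shown leave open how much of the five-membered ring this aromatic carbon needs to carry for a definite number to appear, and whether a carboxylic acid or an amine there would give one. They also leave open whether any change at this place can lower the number of compound 1.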